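From 4-fluorophenyl to 4-chlorophenyl

This account rests on a few compounds, and the source may have more. Where it says the series, first, only, none or still open, it means among the compounds named here.

- compound 1 `Fc1ccc(NCn2nc(-c3ccc4c(c3)OCCO4)oc2=S)cc1` gives 6480 nM here
- compound 2 `FC(F)(F)c1cc(NCn2nc(-c3ccc4c(c3)OCCO4)oc2=S)cc(C(F)(F)F)c1` gives 9320 nM here

Going by the values given here, in a functional assay, with a stated time of 6 min (on this read-out higher numbers stand for weaker inhibition and lower numbers for stronger inhibition), the numbers for compound 1 and compound 2 lie within the scatter of each other, so compound 1 stands level with the only other measured compound. Compound 3 `S=c1oc(-c2ccc3c(c2)OCCO3)nn1CNc1ccc(Cl)cc1` has chloro in place of fluoro on an aromatic carbon, para to a large group (chloro in place of fluoro on an aromatic carbon). Among the compounds with values here, no measured step covers this change, so no step beyond the scatter is expected in this assay in either direction. The expected change is a 1.1-fold lower number from compound 1 to compound 3 (0.03 log units; within the scatter) by estimate only. For compound 3 the estimated value is 6000 nM with an expected range from 2500 nM to 14000 nM on this read-out.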

Compound 3, half-maximal inhibitory concentration: 7270 nM
For compound 3 the middle estimate is 1.2-fold (0.08 log units) below the measured one, and the stated range covers the measured number.
By their numbers in this assay, from the lowest: compounds 1, 3 and 2 (each within the scatter of the next).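

In this assay, chloro in place of fluoro on an aromatic carbon, para to a large group, gives a 1.1-fold higher number from compound 1 to compound 3 (0.05 log units; within the scatter). Going by these compounds alone, this is the first direct reading at this position, and it shows that exchanging these two halogens leaves the number level. No measurement in hand offers an explanation for this result. Still open, from the compounds shown here alone, is whether a methoxy group, an amine or a carboxylic acid at this same place would shift the number beyond the scatter. Also open, going by these compounds, is whether a change to the shared core would do so.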